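Adding an Aromatic Ester to an Inactive Compound

The source may report more compounds than this note shows. Statements on the series, on what has been measured and on what is new or still open speak of the compounds shown alone.

In a functional assay on Caco-2 cells (Homo sapiens) for cytotoxicity, read by MTT assay, with a stated time of 4 h (on this read-out lower numbers stand for stronger inhibition and higher numbers for weaker inhibition), three related compounds have been tested. Compound 1 (`COC(=O)C1=CO[C@@H](O[C@@H]2O[C@H](COC(c3ccccc3)(c3ccccc3)c3ccccc3)[C@@H](OC(=O)O)[C@H](OC(C)=O)[C@H]2OC(C)=O)[C@@H]2[C@@H](C)[C@@H](OC(C)=O)C[C@H]12`) gives 3.45 ug/mL as its result. Compound 2 (`COC(=O)C1=CO[C@@H](O[C@@H]2O[C@H](CO)[C@@H](OC(C)=O)[C@H](OC(C)=O)[C@H]2OC(C)=O)[C@@H]2[C@@H](C)[C@@H](OC(C)=O)C[C@H]12`) gives "not active" (no number reported) as its result, so it has no single number and sits with the entries that lack one. Compound 3 (`C=CC(=O)OC[C@H]1O[C@@H](O[C@@H]2OC=C(C(=O)OC)[C@H]3C[C@H](OC(C)=O)[C@H](C)[C@@H]23)[C@H](OC(C)=O)[C@@H](OC(C)=O)[C@@H]1OC(C)=O`) likewise gives "not active" (no number reported) as its result.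

The next compound to be tested is compound 4 (`COC(=O)C1=CO[C@@H](O[C@@H]2O[C@H](COC(=O)c3cccc([N+](=O)[O-])c3)[C@@H](OC(C)=O)[C@H](OC(C)=O)[C@H]2OC(C)=O)[C@@H]2[C@@H](C)[C@@H](OC(C)=O)C[C@H]12`). The structural change is (3-nitrophenyl)carbonyl in place of hydrogen on an oxygen on a saturated carbon, which puts (3-nitrophenyl)carbonyl in place of hydrogen on an oxygen on a saturated carbon.

Of the tested compounds, only compound 1 carries aromatic rings, and it gives 3.45 ug/mL as its result. On that slim evidence, a step towards stronger inhibition is expected in this assay, from no number to a measurable one. Its size cannot be stated without a number for the starting point, and a second "not active" result remains quite possible. Compound 4 is estimated at 10 ug/mL, with an expected range of 2 ug/mL to 50 ug/mL.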

Compound 4, half-maximal inhibitory concentration: 1 ug/mL
Estimate against measurement, compound 4: 10-fold (1.00 log units) above, outside the stated range (below it).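

Within the data shown here, compound 4 gives 1 ug/mL but compound 2 is reported as not active, without a number, so no step between them can be read. As far as these compounds go, the size of the change on adding (3-nitrophenyl)carbonyl stays open. No measured evidence bears on this result.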